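This account rests on a few compounds, and the source may have more. Where it says the series, first, only, none or still open, it means among the compounds named here.

Working notes on the series.

Among the measured compounds shown here, the series so far holds three measured compounds. Compound 1, `C=C1C[C@]23C[C@@]1(O)CC[C@H]2c1ccc(OS(=O)(=O)c2ccc(C)cc2)c(C)c1[C@@H]3Cn1cc(-c2ccc(Br)cc2)nn1`, is assayed in a functional assay on HL-60 cells (Homo sapiens) for cytotoxicity, read by MTT assay, with a stated time of 4 days; a lower number here means a stronger inhibitor, a higher number a weaker inhibitor; compound 1 reaches only the limit of > 20000 nM, which is a limit of the assay and not a number. Compound 2, `Cc1c(O)ccc2c1[C@H](Cn1cc(-c3ccccc3)nn1)[C@@]13CC(=O)[C@@](C)(CC[C@@H]21)C3`, in this assay likewise gives > 20000 nM, again a limit rather than a number. Compound 3, `C=C1C[C@]23C[C@@]1(O)CC[C@@H]2c1cccc(C)c1[C@@H]3Cn1cc(-c2ccccc2)nn1`, in this assay also sits at > 20000 nM, once more a limit. All three values therefore tell the same thing: the limit of > 20000 nM in this assay, at which 3 of the 3 values shown sit. For the measured compounds named here, no step between measured compounds can be counted, since no pair of them differs in one place, and nothing here separates compound 2 from the others.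

The compound now to be measured is compound 4, `Cc1ccc(-c2cn(C[C@H]3c4c(ccc(O)c4C)[C@@H]4CC[C@@]5(C)C[C@]43CC5=O)nn2)cc1`. It differs from compound 2 as follows: methyl in place of hydrogen on an aromatic carbon. The expected step in this assay is a step that the limit leaves unreadable from compound 2 to compound 4, that is, none beyond the scatter, because compound 2 itself gives only the limit > 20000 nM. Compound 4 is estimated at 30000 nM, with a range from 8000 nM to 100000 nM, and most likely it too will be reported only as a limit.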

Compound 4, half-maximal inhibitory concentration: > 20000 nM
Compound 4: no number, only a limit (the forecaster's own chance of this, stated with the estimate: 85%); the middle value lies beyond the limit too.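

No step can be read from compound 2 to compound 4, as each gives only a limit and not a number. The compounds shown leave open whether any change to the shared core gives a readable value in this assay, since all share one result: the limit of > 20000 nM in this assay, at which 4 of the 4 values shown sit.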